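Sulfide to Sulfone on the Side Chain: Cytotoxicity Outlook

The source may report more compounds than this note shows. Statements on the series, on what has been measured and on what is new or still open speak of the compounds shown alone.

Compound 1 `CCOC(=O)CCN1C(=O)c2ccccc2C(CC(=O)c2ccccc2)C1=O`: > 100 uM
Compound 2 `CSCCCN1C(=O)c2ccccc2C(CC(=O)c2ccccc2)C1=O`: 63 uM

In an ADME assay on HeLa cells (Homo sapiens) for cytotoxicity, read by XTT assay (on this read-out lower numbers stand for higher toxicity in this test and higher numbers for lower toxicity in this test), compound 1 reaches only the assay limit, > 100 uM. Among the measured compounds shown here, compound 2 gives 63 uM, the single plain number among the two values, and the step of an at least 1.5-fold lower number from compound 1 to compound 2 (0.20 log units; that floor lies within the scatter) is read against that limit (the limit of > 100 uM in this assay, at which 1 of the 2 values shown sits). Compound 3 `CS(=O)(=O)CCCN1C(=O)c2ccccc2C(CC(=O)c2ccccc2)C1=O` differs from compound 2 by methylsulfonyl in place of methylsulfanyl on a saturated chain carbon, three bonds along the chain from an amide-type nitrogen in a ring. For the measured compounds named here, no measured step changes a sulfide into a sulfone, so only the step from compound 1 to compound 2 offers any guide, and it stays within the scatter. The step of a 1.3-fold higher number from compound 2 to compound 3 (0.10 log units; within the scatter) is therefore expected to be small. Compound 3 is estimated at 80 uM, between 35 uM and 180 uM.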

Compound 3, half-maximal toxic concentration: > 100 uM
Compound 3 was reported as a limit; the forecaster's own chance of this, stated with the estimate: 40%; at least 1.2-fold (0.09 log units) between middle value and limit.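

In this assay, methylsulfonyl in place of methylsulfanyl on the propyl chain gives an at least 1.5-fold higher number from compound 2 to compound 3 (0.20 log units; that floor lies within the scatter), so this first look at a change on the sulfur shows no sign of a number lower than that of compound 2. Because compound 3 is reported only as a limit, the true size of this step cannot be read, and it may or may not lie beyond the scatter. Compound 1 and compound 3 both stand at that limit, so the step between them cannot be read either: the limit of > 100 uM in this assay, at which 2 of the 3 values shown sit.

On these data alone, how a sulfoxide, an amine or a carboxylic acid would read at the end of this chain remains open. So does the effect of a longer chain.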